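Hydroxy in Place of Hydrogen: Expecting Compound 4

This account rests on a few compounds, and the source may have more. Where it says the series, first, only, none or still open, it means among the compounds named here.

Three compounds have been measured in a functional assay on PC-3 cells (Homo sapiens) for inhibition; a higher number here means a weaker inhibitor, a lower number a stronger inhibitor:

Compound 1 `Cc1c(C(=O)N/N=C\c2ccccc2O)oc2cccc(O)c12` gives 8350 nM.
Compound 2 `Cc1ccc(O)c(/C=N\NC(=O)c2oc3cccc(O)c3c2C)c1` gives 7350 nM.
Compound 3 `Cc1c(C(=O)N/N=C\c2cc(F)ccc2O)oc2cccc(O)c12` gives 3170 nM.

Compound 1 gives the highest of the three numbers, although the step of a 1.1-fold lower number from compound 1 to compound 2 (0.06 log units; within the scatter) is within the scatter, so the two cannot be told apart. The step of a 2.6-fold lower number from compound 1 to compound 3 (0.42 log units; beyond the scatter) is beyond the scatter, as is the step of a 2.3-fold lower number from compound 2 to compound 3 (0.37 log units; beyond the scatter), both modest.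

Compound 4 `Cc1c(C(=O)N/N=C\c2ccc(O)cc2O)oc2cccc(O)c12` is the next compound. It differs from compound 1 by hydroxy in place of hydrogen on an aromatic carbon. For the measured compounds named here, no measured step puts a hydroxy group in this place; the nearest comparisons are the methyl step and the fluoro step on the same ring, which gave a 1.1-fold lower number from compound 1 to compound 2 (0.06 log units; within the scatter) and a 2.6-fold lower number from compound 1 to compound 3 (0.42 log units; beyond the scatter). One of these stayed within the scatter and the other brought only a modest change, so a hydroxy group here is expected to leave the number close to that of compound 1, perhaps a little lower. The step expected here is a 1.2-fold lower number from compound 1 to compound 4 (0.08 log units; within the scatter). This expected step is not thought to exceed the scatter with any confidence. Compound 4 is therefore estimated at 7000 nM, within a range from 2500 nM to 20000 nM.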

Compound 4, half-maximal inhibitory concentration: 14800 nM
Compound 4: the middle estimate sits 2.1-fold (0.33 log units) below what was measured; low and high end bracket the measured number.
By their numbers in this assay, from the lowest: compound 3; then compounds 2, 1 and 4 (each within the scatter of the next).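

Hydroxy in place of hydrogen, at the spot para to a large group and meta to a hydroxy group, gives a 1.8-fold higher number from compound 1 to compound 4 (0.25 log units; within the scatter) in this assay and so cannot be told apart from leaving the hydrogen in place. The comparison with the methyl compound reads the same way, with a 2.0-fold higher number from compound 2 to compound 4 (0.30 log units; within the scatter) for the swap of the whole ring, whereas the fluoro compound does separate, with a 4.7-fold higher number from compound 3 to compound 4 (0.67 log units; beyond the scatter) as a modest gap. Going from 2-hydroxyphenyl to 2,4-dihydroxyphenyl therefore adds one hydrogen-bond donor and one hydrogen-bond acceptor without bringing the number down, and compound 3 remains the only one of the four whose number stands clearly lower than all the others.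

Nothing available here explains why the fluoro compound stands apart while the hydroxy compound does not. From the compounds shown here alone, it also remains open whether a fluoro group at this same spot would match compound 3, and whether a methoxy group, an amine or a carboxylic acid placed there would stay within the scatter of compound 1 or move the number clearly in either direction.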